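Ring-nitrogen substituent size and agonist potency

The source may report more compounds than this note shows. Statements on the series, on what has been measured and on what is new or still open speak of the compounds shown alone.

Compound 2 `CCN1C(=O)c2cc(C)nc(Oc3cccc(NS(=O)(=O)c4ccc(Cl)cc4)c3)c2C1=O` stands with the lowest of the two measured numbers: in a functional assay on HEK293 cells for agonist activity at Glucose-dependent insulinotropic receptor (Homo sapiens), read by cAMP accumulation, with a stated time of 30 min (on this read-out lower numbers stand for an effect already at smaller amounts and higher numbers for an effect only at larger amounts of compound), compound 2 gives 11 nM, while compound 1 `Cc1cc2c(c(Oc3cccc(NS(=O)(=O)c4ccc(Cl)cc4)c3)n1)C(=O)N(C)C2=O` gives 23 nM. For the measured compounds named here, the single measured step, a 2.1-fold lower number from compound 1 to compound 2 (0.32 log units; beyond the scatter), is the only one that bears on the next change, since it also alters the group on the same nitrogen. Compound 3 `Cc1cc2c(c(Oc3cccc(NS(=O)(=O)c4ccc(Cl)cc4)c3)n1)C(=O)N(C1CCCC1)C2=O` differs from compound 2 by cyclopentyl in place of ethyl on an amide-type nitrogen in a ring. Growing the group on this nitrogen from methyl to ethyl gave a modest lowering; cyclopentyl is a larger change at the same place, but no measured pair covers it, so its direction beyond the scatter cannot be read from the data. A small lowering or no change beyond the scatter is expected. Compound 3 is therefore estimated at 9 nM, with a range of 3 nM to 30 nM. This corresponds to an expected step of a 1.2-fold lower number from compound 2 to compound 3 (0.09 log units; within the scatter).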

Compound 3, half-maximal effective concentration: 69 nM
Compound 3: the middle estimate sits 7.7-fold (0.88 log units) below what was measured; measured number outside the range, above it.
By their numbers in this assay, from the lowest: compound 2; then compound 1; then compound 3.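

At this amide-type nitrogen in a ring, the number in this assay does not keep falling as the group grows: cyclopentyl reverses the direction seen on going from methyl to ethyl, giving a 6.3-fold higher number from compound 2 to compound 3 (0.80 log units; beyond the scatter) and also a 3.0-fold higher number from compound 1 to compound 3 (0.48 log units; beyond the scatter) when set against methyl. Among these three groups the order therefore does not follow heavy-atom count, since ethyl gives the lowest number and cyclopentyl, with its 5 heavy atoms and one ring, gives a number higher than both smaller groups. Nothing at hand bears on why the direction turns.

Still open, on these data alone, is where between ethyl and cyclopentyl the turn lies, and whether propyl, isopropyl or cyclopropyl would separate added length from the ring itself. Also open, as far as these compounds go, is how a methoxyethyl group or an amine-bearing chain at this nitrogen would compare.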